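A few compounds are considered here, and "the series" means these few. Any claim that something is new, unique, unknown or untested is made for them only; others in the source may bear on it.

Of the compounds shown here, three sharing one core have been measured so far in a functional assay on HepG2 cells (Homo sapiens) for antiproliferative activity, read by MTT assay, with a stated time of 48 h (a higher number here means a weaker inhibitor, a lower number a stronger inhibitor), and all give numbers in a narrow band. Compound 1 (`COc1ccc(C2OC(c3ccc4ccccc4c3)=NN2C(C)=O)cc1`) reads 3.6 ug/mL in this test. Compound 2 (`CC(=O)N1N=C(c2ccc3ccccc3c2)OC1c1ccc(Cl)cc1`) reads 1.88 ug/mL there, and compound 3 (`CC(=O)N1N=C(c2ccc3ccccc3c2)OC1c1ccccc1F`) reads 3.36 ug/mL on the same scale. Compound 3 thus lies closest to compound 1 and furthest from compound 2, with both gaps inside the scatter. The unmeasured compound 4 (`CC(=O)N1N=C(c2ccc3ccccc3c2)OC1c1ccc(F)cc1`) differs from compound 3 by one change (4-fluorophenyl in place of 2-fluorophenyl on a saturated ring carbon): 4-fluorophenyl in place of 2-fluorophenyl on a saturated ring carbon. Within the data shown here, no measured step shows this exact swap. The closest evidence is the swaps at that same ring carbon, namely a 1.8-fold higher number from compound 2 to compound 3 (0.25 log units; within the scatter) and a 1.1-fold lower number from compound 1 to compound 3 (0.03 log units; within the scatter) together with a 1.9-fold lower number from compound 1 to compound 2 (0.28 log units; within the scatter) on an aromatic carbon. None of these steps leaves the scatter, so no step beyond the scatter is expected for compound 4 in this assay and neither direction is favoured. The expected move is small, and it is estimated as a 1.2-fold lower number from compound 3 to compound 4 (0.08 log units; within the scatter) at most a drift toward the middle of the band. Compound 4 is estimated at 2.8 ug/mL in this assay with an expected range of 1.6 ug/mL to 5 ug/mL around that figure.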

Compound 4, half-maximal inhibitory concentration: 1.82 ug/mL
Compound 4: the middle estimate sits 1.5-fold (0.19 log units) above what was measured, within the range that was stated.
By their numbers in this assay, from the lowest: compounds 4, 2, 3 and 1 (each within the scatter of the next).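

Among these compounds, compound 3 and compound 4 are the first pair that carries the same halogen and differs only in where it sits on the phenyl group: 4-fluorophenyl in place of 2-fluorophenyl on the saturated ring carbon gives a 1.8-fold lower number from compound 3 to compound 4 (0.27 log units; within the scatter) in this assay and so does not separate the two placements of the fluorine. The new compound also adds two swaps on the aromatic carbon of that phenyl group, where fluoro in place of chloro gives a 1.0-fold lower number from compound 2 to compound 4 (0.01 log units; within the scatter) and fluoro in place of methoxy gives a 2.0-fold lower number from compound 1 to compound 4 (0.30 log units; within the scatter) and thus shows that this assay does not distinguish among the fluoro, chloro and methoxy groups there. Nothing offered here accounts for these numbers.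

Every compound shown carries a phenyl group with a fluoro, chloro or methoxy group at this carbon, so it remains open whether a phenyl group bearing an amine or a carboxylic acid would leave the narrow band. The acetyl group and the rest of the shared core stay the same throughout, which leaves open what a longer chain in place of that acetyl group would do.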